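This account rests on a few compounds, and the source may have more. Where it says the series, first, only, none or still open, it means among the compounds named here.

The measured compounds in a functional assay on MDA-MB-231 cells (Homo sapiens) for antiproliferative activity, read by sulforhodamine B assay, with a stated time of 48 h; a higher number here means a weaker inhibitor, a lower number a stronger inhibitor:

Compound 1, `COc1cc(OC)c2sc(-c3ccc(N/C=C\C(=O)c4ccc(OC)c(O)c4)c(C)c3)nc2c1`, gives 3100 nM.
Compound 2, `COc1cc(OC)c2sc(-c3ccc(N/C=C\C(=O)c4ccc(OC)c(O)c4)cc3)nc2c1`, gives 7610 nM.
Compound 3, `COc1ccc2nc(-c3ccc(N/C=C\C(=O)c4cc(OC)c(OC)c(OC)c4)c(C)c3)sc2c1`, gives 17000 nM.

Compound 4, `COc1ccc2nc(-c3ccc(N/C=C\C(=O)c4cc(OC)c(OC)c(OC)c4)cc3)sc2c1`, has not yet been measured in this assay. It differs from compound 3 in one place: hydrogen in place of methyl on an aromatic carbon. The same kind of change has already been made once, from compound 1 to compound 2: hydrogen in place of methyl on an aromatic carbon. That step gave a 2.5-fold higher number from compound 1 to compound 2 (0.39 log units; beyond the scatter). The two cases are not identical in their surroundings, though: in compound 1 the carbon carrying the methyl is meta to a large group, while in compound 3 it is meta to a 6-methoxy-1,3-benzothiazol-2-yl group. The difference between the core of compound 1 and the core of compound 3 is not broken down here. Compound 3 has the highest number of the three measured compounds; its value lies beyond the scatter above that of compound 2 and further still above that of compound 1.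

Among the compounds with values here, with only one earlier instance of the change, the expectation for compound 4 rests on that single step. Compound 4 is expected to show a step of a 2.4-fold higher number from compound 3 to compound 4 (0.37 log units; beyond the scatter) from compound 3, close in size to a 2.5-fold higher number from compound 1 to compound 2 (0.39 log units; beyond the scatter), with added uncertainty since the surroundings differ. Compound 4 is therefore estimated at 40000 nM in this assay, within a range from 15000 nM to 100000 nM.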

Compound 4, half-maximal inhibitory concentration: 19600 nM
Estimate against measurement, compound 4: 2.0-fold (0.31 log units) above; measured number inside the range.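

In this assay, putting hydrogen in place of methyl on an aromatic carbon gives a 1.2-fold higher number from compound 3 to compound 4 (0.06 log units; within the scatter), so on this core the change leaves no difference that can be told from the usual scatter. Set beside the earlier case, the two steps do not differ by more than the scatter of two such steps, and the data therefore give no ground for saying that the change behaves differently on the two cores: the same change on two cores in this assay, a 2.5-fold higher number (0.39 log units; beyond the scatter) from compound 1 to compound 2 and a 1.2-fold higher number (0.06 log units; within the scatter) from compound 3 to compound 4, 2.1-fold (0.33 log units) apart, within the scatter of two such steps. This does not show that the step has the same size on every core: there are only two instances, one beyond the scatter and one within it, and the cores of compound 1 and compound 3 differ in more than one place, which leaves unresolved whether any one part of the core bears on the size of the step.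

The compounds shown carry only methyl or hydrogen at this place, which leaves open how an ethyl group, a methoxy group or a chlorine atom there would read in this assay. They also leave open whether the step would hold on a core carrying an amine or a carboxylic acid in place of one of its methoxy groups.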